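This account rests on a few compounds, and the source may have more. Where it says the series, first, only, none or still open, it means among the compounds named here.

Measured compounds and values:
- compound 1 `CCOC(=O)C1=Cc2ccccc2OC1(OCc1cn(-c2ccc(F)cc2)nn1)C(F)(F)F` — 8900 nM
- compound 2 `CCOC(=O)C1=Cc2ccccc2OC1(OCc1cc(-c2ccc(Cl)cc2)no1)C(F)(F)F` — 18200 nM
- compound 3 `CCOC(=O)C1=Cc2ccccc2OC1(OCc1cn(CC(=O)Nc2cccc(F)c2)nn1)C(F)(F)F` — > 150000 nM, a limit of the assay, not a number

All three share one core and differ only in the substituent on the ether-linked heteroaromatic ring. In a functional assay on DU-145 cells (Homo sapiens) for inhibition, read by MTT assay, with a stated time of 24 h (a lower number here means a stronger inhibitor, a higher number a weaker inhibitor), compound 2 gives 18200 nM, the highest of the two numbers recorded; the nearest number is that of compound 1, which gives 8900 nM. For compound 3 the assay reports only (the limit of > 150000 nM in this assay, at which 1 of the 3 values shown sits).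

Among the compounds with values here, the single step measured, an at least 16-fold higher number from compound 1 to compound 3 (1.22 log units; beyond the scatter), concerns the group on the aromatic nitrogen and not a halogen on a phenyl ring, so it does not bear on the change considered here.

Compound 4 `CCOC(=O)C1=Cc2ccccc2OC1(OCc1cc(-c2ccc(F)cc2)no1)C(F)(F)F` differs from compound 2 by fluoro in place of chloro on an aromatic carbon. Within the data shown here, no measured pair shows this exchange, so there is no step on record to set its size. The expectation in this assay is therefore a step no larger than the usual scatter, in either direction: a 1.2-fold lower number from compound 2 to compound 4 (0.08 log units; within the scatter). For compound 4 the estimated value in this assay is 15000 nM, with a range from 6000 nM to 40000 nM.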

Compound 4, half-maximal inhibitory concentration: 53500 nM
For compound 4 the middle estimate is 3.6-fold (0.55 log units) below the measured one; the measured number lies above the stated range.
By their numbers in this assay, from the lowest: compound 1; then compound 2; then compound 4. At a limit, above all of these: compound 3.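

In this assay, the exchange of fluoro for chloro gives a 2.9-fold higher number from compound 2 to compound 4 (0.47 log units; beyond the scatter), so a change of halogen alone at this place, para to a large group, moves the number beyond the scatter, with the chloro compound the stronger of the pair. Within the data shown here, the earlier step concerned only the group on the aromatic nitrogen, so this is the first reading of the halogen itself, and it rests on a single pair on one heteroaromatic ring. Nothing measured here gives a cause for this step.

As far as these compounds go, whether the same order of chloro and fluoro holds on the different heteroaromatic ring of compound 1, or at another carbon of the phenyl ring, stays open. From the compounds shown here alone, it is also open how this place responds to groups other than the two halogens, such as bromo, methyl, methoxy, an amine or a carboxylic acid, and so whether the step from chloro to fluoro is part of a wider trend or stands alone.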